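Acetoxy to ethoxy on the shared core

A few compounds are considered here, and "the series" means these few. Any claim that something is new, unique, unknown or untested is made for them only; others in the source may bear on it.

The series is followed in a functional assay on KB cells (Homo sapiens) for cytotoxicity, read by MTT assay, with a stated time of 72 h; a higher number here means that more compound is needed for the effect, a lower number that less compound is needed. Compound 1 `CCOc1c(-c2occ(C)c2CO)ccc2c(CC)cccc12` gives > 10 ug/mL there, which is a limit of the assay and not a number. Compound 2 `CCc1cccc2c(OC(C)=O)c(-c3occ(C)c3COC(C)=O)ccc12` likewise gives > 10 ug/mL in this assay, again a limit rather than a measured value. Compound 3 `CCc1cccc2c(OC)c(-c3occ(C)c3CBr)ccc12` gives > 10 ug/mL, once more only a limit. Among the measured compounds shown here, compound 2 therefore stands exactly where every value shown stands, at the limit of > 10 ug/mL in this assay, at which 3 of the 3 values shown sit, and no step between measured compounds exists to set a scale for any structural change in this assay.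

Compound 4 `CCOc1c(-c2occ(C)c2COC(C)=O)ccc2c(CC)cccc12` has not been measured in this assay. It differs from compound 2 in one place: ethyl in place of acetyl on an oxygen on an aromatic ring. The change is small in count, and nothing among the three measured compounds separates an ethoxy from an acetoxy, since all three sit at the same limit. The step from compound 2 to compound 4 is expected to be none beyond the scatter, a step that the limit leaves unreadable from compound 2 to compound 4. Compound 4 is accordingly expected to give about 15 ug/mL, within a range of 5 ug/mL to 50 ug/mL, and most likely to be reported again only as a limit.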

Compound 4, concentration for half-maximal effect: > 10 ug/mL
Compound 4: a limit, no number; the forecaster's own chance of this, stated with the estimate: 80%; the middle value is on the limit's open side.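

Compound 4 gives > 10 ug/mL in this assay, again a limit and not a number. The steps to compound 4 from compound 2 and from compound 1 cannot be read, because every value shown stands at one limit: the limit of > 10 ug/mL in this assay, at which 4 of the 4 values shown sit.

The compounds shown leave open whether ethoxy and acetoxy on the shared core differ at all in this assay.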